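The compounds below may be only part of what the source reports. "The series", "measured", "known", "first", "only" and "open" are said of these compounds alone.

Measured in a functional assay on the whole organism (strain Sprague-Dawley) for inhibition, with Rattus norvegicus as the target, with a stated time of 10 min; a higher number here means that more compound is needed for the effect, a lower number that less compound is needed:
compound 1 `CC(C)Oc1ccccc1-c1ncc(C(=O)O)c(=O)[nH]1`: 0.8 mg/kg
compound 2 `O=C(O)c1cnc(-c2ccc(Cl)cc2)[nH]c1=O`: 5 mg/kg

Of these two compounds, compound 2 stands highest in this assay at 5 mg/kg, so it needs the larger dose. Its nearest neighbour, compound 1, has a lower number at 0.8 mg/kg, and that gap lies beyond the usual scatter. Among the compounds with values here, the two differ in more than one place, so no measured step isolates a single change.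

Compound 3 `COc1ccc(-c2ncc(C(=O)O)c(=O)[nH]2)cc1` has not yet been measured. It departs from compound 2 by one change: methoxy in place of chloro on an aromatic carbon, which is methoxy in place of chloro on an aromatic carbon. Within the data shown here, with no measured precedent for this swap, a large shift is not anticipated. The expected step of a 1.3-fold lower number from compound 2 to compound 3 (0.10 log units; within the scatter) is estimated to stay within the scatter, with a slight lean toward a lower number. For compound 3 the estimated dose is 4 mg/kg, with an expected range of 1.5 mg/kg to 10 mg/kg.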

Compound 3, dose for 50% inhibition: > 5 mg/kg
Compound 3 ended at the assay's limit; the forecaster's own chance of this, stated with the estimate: 5%; middle value at least 1.2-fold (0.09 log units) from the limit.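

In this assay, compound 3 gives > 5 mg/kg, which is a limit of the assay and not a number. Within the data shown here, compound 2 and compound 3 form the first pair here that differs in one place, and methoxy in place of chloro on the aromatic carbon para to a large group gives a number no lower from compound 2 to compound 3 (the limit leaves the size open), so this change brings no lower dose, while the size of the step cannot be read. The result therefore gives a direction only, and it sits at the edge of what the assay reports: the limit of > 5 mg/kg in this assay, at which 1 of the 3 values shown sits.

From the compounds shown here alone, how far methoxy actually lies from chloro at this position remains open. So does whether an amine or a fluoro group on the same aromatic carbon would give a readable number in this assay.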